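Trading a Methoxy for a Hydroxy Group

The compounds below may be only part of what the source reports. "The series", "measured", "known", "first", "only" and "open" are said of these compounds alone.

Compound 2 `COc1cc(-c2nn(-c3cccc(NC(=O)Nc4ccc(Cl)c(C(F)(F)F)c4)c3)cc2-c2ccncc2)ccc1Cl` was tested in a functional assay on 786-0 cells (Homo sapiens) for inhibition, read by sulforhodamine B assay, with a stated time of 48 h (on this read-out higher numbers stand for weaker inhibition of growth and lower numbers for stronger inhibition of growth), where compound 2 gives 8020 nM. For the measured compounds named here, that is the only real number in the set; the one other result is a limit rather than a number. Compound 1 `O=C(Nc1cccc(-n2cc(-c3ccncc3)c(-c3ccc(Cl)c(O)c3)n2)c1)Nc1ccc(Cl)c(Cl)c1` also bears a hydroxy group on its ring, and in this assay compound 1 reaches only a limit of > 32500 nM. Compound 2 therefore stands alone as the single measured point.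

Compound 3 `O=C(Nc1cccc(-n2cc(-c3ccncc3)c(-c3ccc(Cl)c(O)c3)n2)c1)Nc1ccc(Cl)c(C(F)(F)F)c1` has not yet been measured. It differs from compound 2 by hydrogen in place of methyl on an oxygen on an aromatic ring, turning methoxy into hydroxy. Going by the values given here, no measured pair isolates this swap, so the expectation rests on (the limit of > 32500 nM in this assay, at which 1 of the 2 values shown sits), the only other hydroxy-bearing result. The step from compound 2 to compound 3 is expected to be a 2.5-fold higher number from compound 2 to compound 3 (0.40 log units; beyond the scatter), towards weaker inhibition and beyond the scatter. Compound 3 is estimated at 20000 nM, within 6000 nM to 40000 nM.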

Compound 3, concentration for total growth inhibition: > 32500 nM
Compound 3 was reported as a limit; the forecaster's own chance of this, stated with the estimate: 40%; middle value at least 1.6-fold (0.21 log units) from the limit.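

In this assay, turning methoxy into hydroxy on the 4-chloro-3-methoxyphenyl group gives an at least 4.0-fold higher number from compound 2 to compound 3 (0.60 log units; beyond the scatter), towards weaker inhibition of growth. For the compounds shown here, this is the first pair in the set that isolates this one swap, so the loss can be tied to replacing methyl with hydrogen on that oxygen, at least with the trifluoromethyl group present. The step between compound 1 and compound 3, trifluoromethyl in place of chloro, cannot be read, because both compounds sit at the same limit: the limit of > 32500 nM in this assay, at which 2 of the 3 values shown sit.

Going by these compounds, how far the two hydroxy compounds lie past that limit remains open, and with it the full size of the step. Also open, on these data alone, is whether ethoxy, with its longer chain on that oxygen, or an amine in place of methoxy would match compound 2.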